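The source may report more compounds than this note shows. Statements on the series, on what has been measured and on what is new or still open speak of the compounds shown alone.

Measured so far in an ADME assay on A549 cells (Homo sapiens) for cytotoxicity, read by CellTiter-Glo; a lower number here means that less compound is tolerated, a higher number that more compound is tolerated:
compound 1, `Cc1c(Cc2ccccc2)c(=O)oc2cc(OCC(O)CNCc3ccccc3)ccc12`: > 100000 nM
compound 2, `Cc1noc(C)c1-c1ccc(Cc2c(C)c3ccc(OCC(O)CN4CCC(C(N)=O)CC4)cc3oc2=O)cc1`: 36900 nM

Compound 1 sits at the limit of > 100000 nM in this assay, at which 1 of the 2 values shown sits; its figure is a limit of the assay and not a number. Among the compounds with values here, compound 2 therefore supplies the only actual number in this assay, and there is no second measured number against which it could be placed higher or lower.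

Compound 3, `Cc1c(Cc2ccc(-c3ccc(C(F)(F)F)cc3)cc2)c(=O)oc2cc(OCC(O)CN3CCC(C(N)=O)CC3)ccc12`, differs from compound 2 in one place: 4-(trifluoromethyl)phenyl in place of 3,5-dimethyl-1,2-oxazol-4-yl on an aromatic carbon. Within the data shown here, no measured pair shows a change of this kind, so the size of the step can only be guessed. A moderate move toward less tolerated compound is expected, beyond the usual scatter but not by much; the estimated step is a 1.8-fold lower number from compound 2 to compound 3 (0.27 log units; within the scatter). Compound 3 is expected to give about 20000 nM in this assay, with a plausible range from 6000 nM to 70000 nM.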

Compound 3, half-maximal cytotoxic concentration: > 100000 nM
Compound 3: no number, only a limit; the forecaster's own chance of this, stated with the estimate: 10%; at least 5.0-fold (0.69 log units) between middle value and limit.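

In this assay, 4-(trifluoromethyl)phenyl in place of 3,5-dimethyl-1,2-oxazol-4-yl, on an aromatic carbon para to a large group, gives an at least 2.7-fold higher number from compound 2 to compound 3 (0.43 log units; beyond the scatter). Compound 3 gives > 100000 nM, which is a limit of the assay and not a number, so the step has a minimum size but no known full size. The ring of carbon only, with no hydrogen-bond acceptors, does not lower the number at this position, and compound 2 remains the only compound with an actual number: the limit of > 100000 nM in this assay, at which 2 of the 3 values shown sit.

The compounds shown leave open whether the ring of carbon only or the trifluoromethyl group carries this step. Plain phenyl or 4-aminophenyl at this carbon would separate the two, and only a compound with a number in this assay would fix the size of the step.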